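A few compounds are considered here, and "the series" means these few. Any claim that something is new, unique, unknown or untested is made for them only; others in the source may bear on it.

Measured so far:
Compound 1 `COc1ccc(C#Cc2ccc(C(=O)N3CCCC(OC)C3)cc2)cc1` gives 5500 nM in a functional assay on TREX cells for negative allosteric modulation of metabotropic glutamate receptor 3 (Rattus norvegicus), read by calcium flux, with a stated time of 2.5 min; a lower number here means a stronger inhibitor, a higher number a weaker inhibitor.
Compound 2 `COc1ccc(C#Cc2ccc(C(=O)N3CCC(CO)C3)cc2)cc1` gives 7590 nM in this assay.

Both measured compounds share the same core and differ only in the group attached to the carbonyl carbon. Going by the values given here, compound 2 is one of only two numbers, and its nearest neighbour is compound 1: the step of a 1.4-fold higher number from compound 1 to compound 2 (0.14 log units; within the scatter) lies within the scatter, so the two compounds cannot be told apart on these data.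

Compound 3 `COc1ccc(C#Cc2ccc(C(=O)N3CC4CCC(=O)C4C3)cc2)cc1` is not yet measured. The change from compound 2 is a group of 9 heavy atoms (7 carbon, 1 nitrogen, 1 oxygen; one five-membered non-aromatic ring of carbon only, one five-membered non-aromatic ring with 1 hetero atom) in place of a group of 7 heavy atoms (5 carbon, 1 nitrogen, 1 oxygen; one five-membered non-aromatic ring with 1 hetero atom), on a carbonyl carbon, a rebuilding of the same attachment point that the measured step also touched. That step, a 1.4-fold higher number from compound 1 to compound 2 (0.14 log units; within the scatter), is the only one that bears on it, and it was small. It shows that swapping one saturated ring at this position for another left the number where it was, but the incoming group here is of a kind not yet tried, so the step of a 1.2-fold lower number from compound 2 to compound 3 (0.07 log units; within the scatter) is expected to be small, with no clear direction beyond the scatter. Compound 3 is therefore estimated at 6500 nM in this assay, within a range of 2000 nM to 20000 nM.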

Compound 3, half-maximal inhibitory concentration: 2750 nM
Beside the measured number, compound 3's estimate is 2.4-fold (0.37 log units) above it, and the stated range covers the measured number.
By their numbers in this assay, from the lowest: compounds 3, 1 and 2 (each within the scatter of the next, the first and the last beyond it).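

In this assay, going by these compounds alone, the rebuilt group on the carbonyl carbon gives the first step at this position that lies beyond the scatter, namely a 2.8-fold lower number from compound 2 to compound 3 (0.44 log units; beyond the scatter), so this attachment point can move the number, which the pair of compounds 1 and 2 could not show. Measured against compound 1, the same group gives a 2.0-fold lower number from compound 1 to compound 3 (0.30 log units; within the scatter) and that step stays within the scatter, so the improvement holds only against compound 2, and compound 3 cannot be told apart from compound 1. The entering group differs from 3-(hydroxymethyl)pyrrolidin-1-yl in several ways at once, with a second ring, a double bond outside aromatic rings and no hydrogen-bond donor, and nothing available here says which of these differences matters.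

The compounds shown leave open whether a plain pyrrolidin-1-yl, carrying no hydroxymethyl, would behave like compound 2 or like compound 3. They also leave open how a ring bearing an amine or a carboxylic acid at this carbonyl carbon would read, and whether any group here can move the number well beyond the small steps seen so far.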